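The source may hold more compounds than are shown below. What is called first, only, known or untested is meant among the compounds shown, and "the series" means these compounds.

Measured compounds:
- compound 1, `CC(C)c1ccc(-n2nc(-c3ccc(C(F)(F)F)cc3O)nc2-c2ccccc2O)cc1`, giving 51400 nM in a toxicity assay on HaCaT cells (Homo sapiens) for cytotoxicity, read by MTT assay; on this read-out higher numbers stand for weaker inhibition and lower numbers for stronger inhibition
- compound 2, `Cc1ccc(-n2nc(-c3ccc(C(F)(F)F)cc3O)nc2-c2ccccc2O)c(C)c1`, giving 94800 nM in this assay

Compound 1 has the lowest of the two numbers recorded in this assay; its nearest neighbour is compound 2, and the step of a 1.8-fold higher number from compound 1 to compound 2 (0.27 log units; within the scatter) lies within the scatter, so the two cannot be ordered. Compound 3, `Cc1cc(C)cc(-n2nc(-c3ccc(C(F)(F)F)cc3O)nc2-c2ccccc2O)c1`, has not been measured in this assay. It differs from compound 1 in one place: 3,5-dimethylphenyl in place of 4-isopropylphenyl on an aromatic nitrogen. Within the data shown here, the one measured step that bears on this change is a 1.8-fold higher number from compound 1 to compound 2 (0.27 log units; within the scatter), which also exchanges the 4-isopropylphenyl for a dimethylphenyl group on the aromatic nitrogen and stayed within the scatter. Compound 3 is therefore expected to sit close to compound 1 and compound 2, with no step beyond the scatter in this assay; the expected step is a 1.4-fold higher number from compound 1 to compound 3 (0.13 log units; within the scatter). The estimate for compound 3 in this assay is 70000 nM, expected to fall between 30000 nM and 160000 nM.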

Compound 3, half-maximal inhibitory concentration: 127000 nM
For compound 3 the middle estimate is 1.8-fold (0.26 log units) below the measured one; measured number inside the range.
By their numbers in this assay, from the lowest: compounds 1, 2 and 3 (each within the scatter of the next, the first and the last beyond it).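

In this assay, among these compounds, the exchange of 4-isopropylphenyl for 3,5-dimethylphenyl on the aromatic nitrogen gives the only step at this position that lies beyond the scatter (a 2.5-fold higher number from compound 1 to compound 3 (0.39 log units; beyond the scatter)), a modest move towards weaker inhibition. The two dimethylphenyl groups are not separated (a 1.3-fold higher number from compound 2 to compound 3 (0.13 log units; within the scatter)), so the placing of the two methyl groups on the ring cannot be ranked from these compounds, and only compound 1 and compound 3 can be told apart. Nothing available explains the difference between the 4-isopropylphenyl and 3,5-dimethylphenyl groups.

All three groups on this nitrogen are phenyl rings carrying only carbon substituents, so the compounds shown leave open how the number would respond to a phenyl ring bearing an amine or a carboxylic acid. They also leave open whether changes to the 2-hydroxyphenyl group would shift it.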